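The compounds below may be only part of what the source reports. "The series", "measured", "known", "first", "only" and "open" are said of these compounds alone.

Measured compounds, all in a functional assay on the whole organism (strain Swiss albino) for inhibition, with Mus musculus as the target, in the writhing test, with a stated time of 30 min, at a dose of 20 mg/kg by the oral route; a higher number here means a stronger effect of the compound at the dose given, a lower number a weaker effect:

Compound 1, `Cc1c(/C=N\O)cc(-c2ccc(S(C)(=O)=O)cc2)n1-c1cccc(F)c1`, gives 42%.
Compound 2, `Cc1c(/C=N\O)cc(-c2ccc(S(C)(=O)=O)cc2)n1-c1ccc(F)c(F)c1`, gives 27%.
Compound 3, `Cc1c(C#N)cc(-c2ccc(S(C)(=O)=O)cc2)n1-c1cccc(F)c1`, gives 33%.

Not yet measured: compound 4, `Cc1c(C#N)cc(-c2ccc(S(C)(=O)=O)cc2)n1-c1ccc(F)c(F)c1`.

Compound 1 and compound 2 share one core and differ by fluoro in place of hydrogen on an aromatic carbon; in this assay this change gave a number 15 percentage points lower from compound 1 to compound 2 (beyond the scatter). Compound 3 and compound 4 share a second core, and the two cores differ by a group of 2 heavy atoms (1 carbon, 1 nitrogen; no ring) in place of a group of 3 heavy atoms (1 carbon, 1 nitrogen, 1 oxygen; no ring), on an aromatic carbon; between the measured members, compound 1 and compound 3, this assay gave a number 9 percentage points lower from compound 1 to compound 3 (within the scatter), so the second core is not set apart from the first by this read-out.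

The change from compound 3 to compound 4 is fluoro in place of hydrogen on an aromatic carbon. Its place reads word for word as the place of the change from compound 1 to compound 2, so it is the same change set on the second core, and it occurs twice among the four compounds. For the measured compounds named here, with only one measured instance there is no way to tell whether the step moves with the core; the single step is the only guide.

For compound 4 the expected step in this assay is therefore a number 13 percentage points lower from compound 3 to compound 4 (beyond the scatter), taken from the step that the same change gave between compound 1 and compound 2, namely a number 15 percentage points lower from compound 1 to compound 2 (beyond the scatter), applied to the value of compound 3, 33%. Compound 4 is thus estimated at 20% in this assay. Going by the values given here, the range for compound 4 is expected to run from 8% to 32%, wider than the single step alone, because the one prior instance a number 15 percentage points lower from compound 1 to compound 2 (beyond the scatter) was itself only modestly beyond the scatter.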

Compound 4, a percentage reported as inhibition, in the whole organism at one dose (the size of the read-out at that dose, not a potency): 38%
The estimate for compound 4 lay 18 percentage points below the measured number; the whole stated range lies below it.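

In this assay, the step from 3-fluorophenyl to 3,4-difluorophenyl does not carry from the core of compound 1 to the core of compound 3: the same change on two cores in this assay, a number 15 percentage points lower (beyond the scatter) from compound 1 to compound 2 and a number 5 percentage points higher (within the scatter) from compound 3 to compound 4, 20 percentage points apart, beyond the scatter of two such steps. On the core of compound 3, the added fluoro gives a number 5 percentage points higher from compound 3 to compound 4 (within the scatter), so no effect of that fluoro can be claimed on this core, while the nitrile, read on the 3,4-difluorophenyl pair, gives a number 11 percentage points higher from compound 2 to compound 4 (beyond the scatter), and its step therefore depends on the aryl group it is paired with: the same change on two cores in this assay, a number 9 percentage points lower (within the scatter) from compound 1 to compound 3 and a number 11 percentage points higher (beyond the scatter) from compound 2 to compound 4, 20 percentage points apart, beyond the scatter of two such steps. The two changes are thus not additive across these four compounds, but this rests on one reading per compound at a single dose and shows neither a reason for the interaction nor a rule that reaches beyond them.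

As far as these compounds go, it remains open whether the same dependence on the core holds when chloro or methoxy stands in place of the added fluoro, or when a carboxylic acid or an amide stands in place of the nitrile. From the compounds shown here alone, it is also open whether the pattern seen at this one dose in this assay would persist at other doses.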